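This account rests on a few compounds, and the source may have more. Where it says the series, first, only, none or still open, it means among the compounds named here.

Compound 1 `O=c1cc(-c2ccccc2)[nH]c(=O)n1O` — an assay on isolated protein for inhibition of Flap endonuclease 1 (Homo sapiens); on this read-out higher numbers stand for weaker inhibition and lower numbers for stronger inhibition: 630 nM
Compound 2 `COc1nc(-c2cccs2)nc(C(=O)O)c1O` — this assay: "not determined" (no result reported)
Compound 3 `O=C(NCCO)c1nc(-c2cccs2)[nH]c(=O)c1O` — this assay: 4000 nM

Two numbers are available in this assay. Compound 1 gives 630 nM, while compound 3 gives 4000 nM, the higher of the two, and the gap between them lies beyond the usual scatter. Compound 2 carries no result, so nothing can be said of where it would stand.

Compound 4 `CC(=O)NCCNC(=O)c1nc(-c2cccs2)[nH]c(=O)c1O` differs from compound 3 in one place: acetamido in place of hydroxy on a saturated chain carbon, two bonds along the chain from an amide-type nitrogen. For the measured compounds named here, no pair of measured compounds shows this change, so its effect in this assay has to be judged from the structures alone. The part of the molecule that changes is the end of the chain hanging from the amide, away from the shared core, and both groups bring one donor and one acceptor. For that reason the step is expected to be small, with no clear direction, and probably within the scatter: the estimated step is no change at the digits printed from compound 3 to compound 4 (within the scatter). Compound 4 is therefore expected to give about 4000 nM in this assay, with a range from 1500 nM to 12000 nM.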

Compound 4, half-maximal inhibitory concentration: 5000 nM
For compound 4 the middle estimate is 1.3-fold (0.10 log units) below the measured one, within the range that was stated.
By their numbers in this assay, from the lowest: compound 1; then compounds 3 and 4 (each within the scatter of the next).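

In this assay, placing acetamido where hydroxy stood on a saturated chain carbon, two bonds along the chain from an amide-type nitrogen, gives a 1.3-fold higher number from compound 3 to compound 4 (0.10 log units; within the scatter). For the compounds shown here, this is the first reading of any single change at this position, and it shows that the assay does not separate the 2-hydroxyethyl and 2-acetamidoethyl chains, even though the group that enters is the larger of the two. Nothing available accounts for this result.

As far as these compounds go, whether an amine or a carboxylic acid at the end of the chain, or a longer chain, would read the same remains open. Going by these compounds alone, the compounds also leave open whether the same change would behave alike on a core other than the one shared by compound 3 and compound 4.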